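Removing a Piperidinyl Group from Compound 3

This account rests on a few compounds, and the source may have more. Where it says the series, first, only, none or still open, it means among the compounds named here.

Measured compounds:
Compound 1 `Cc1cc(=O)c2c(O)cc(OCc3ccc([N+](=O)[O-])cc3)c([C@H]3CCN(C)C[C@H]3O)c2o1`: 12%
Compound 2 `Cc1cc(=O)c2c(O)cc(OCc3ccccc3Br)c([C@H]3CCN(C)C[C@H]3O)c2o1`: 30%
Compound 3 `Cc1cc(=O)c2c(O)c(CN3CCC(N4CCCCC4)CC3)c(O)c([C@H]3CCN(C)C[C@H]3O)c2o1`: 23%

All three were tested in a functional assay on MIA PaCa-2 cells (Homo sapiens) for inhibition, read by MTT assay, with a stated time of 48 h, tested at 10 uM; on this read-out lower numbers stand for less inhibition of growth and higher numbers for more inhibition of growth at the one concentration tested. Compound 3 gives 23%, the second highest of the three numbers; its nearest neighbour is compound 2, which sits within the scatter of it, while compound 1 lies further off, beyond the scatter. Within the data shown here, the one step measured between compounds that differ in a single place, a number 18 percentage points higher from compound 1 to compound 2 (beyond the scatter), concerns the group on a saturated chain carbon bound to an oxygen on an aromatic ring and does not touch the side chain that changes here.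

Compound 4 `Cc1cc(=O)c2c(O)c(CN3CCCCC3)c(O)c([C@H]3CCN(C)C[C@H]3O)c2o1` differs from compound 3 at that side chain: hydrogen in place of piperidin-1-yl on a saturated ring carbon. Among the measured compounds shown here, no measured pair shows what this change does in this assay, and the step from compound 1 to compound 2 is of a different kind, so nothing beyond the scatter is expected in either direction in this assay. The expected step of a number 3 percentage points lower from compound 3 to compound 4 (within the scatter) is therefore small. Compound 4 is estimated at 20%, with a range from 8% to 34%.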

Compound 4, percent growth inhibition at one concentration: 14%
For compound 4 the middle estimate is 6 percentage points above the measured one; the range from low to high includes it.
By their numbers in this assay, from the lowest: compounds 1, 4, 3 and 2 (each within the scatter of the next, the first and the last beyond it).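

Among these compounds, the change of hydrogen in place of piperidin-1-yl gives, in this assay, a number 9 percentage points lower from compound 3 to compound 4 (within the scatter) and is the first reading at this position, on a saturated ring carbon of a six-membered non-aromatic ring with 1 nitrogen. It shows that this carbon can lose a whole six-membered non-aromatic ring of 6 heavy atoms, with its hydrogen-bond acceptor, without a step beyond the scatter, so the piperidin-1-yl group is not shown to matter for the number in this pair. Among the compounds shown here, the earlier compounds could not show this, as their one measured step concerns a different place, and no measurement is at hand that bears on the present step.

Still open, as far as these compounds go, is whether other groups on this saturated ring carbon, such as a dimethylamino group, a hydroxyl, a carboxylic acid or a longer alkyl chain, would move the number beyond the scatter in either direction. Also open, from the compounds shown here alone, is whether the same change would read alike at other concentrations, as this pair gives one reading at a single concentration.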